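A few compounds are considered here, and "the series" means these few. Any claim that something is new, unique, unknown or untested is made for them only; others in the source may bear on it.

Measured so far:
- compound 1, `O=C(CCCCC#Cc1ccncc1)c1ncc(-c2ccccn2)o1`, in an assay for inhibition of Fatty-acid amide hydrolase 1 (Rattus norvegicus) (on this read-out lower numbers stand for stronger inhibition and higher numbers for weaker inhibition), gives 150 nM
- compound 2, `O=C(CCCCCCc1ccc(Cl)cc1)c1ncc(-c2ccccn2)o1`, in this assay gives 2.7 nM

Only these two compounds have numbers. Compound 2 has the lower of the two, so the stronger inhibition, and the number for compound 1 stands higher by a gap that lies well beyond the usual scatter of repeated measurements. Because the two differ in more than one place at once, nothing is known about which part of compound 2 accounts for the gap; the two values show the gap and nothing more.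

Compound 3, `CSc1ccc(CCCCCCC(=O)c2ncc(-c3ccccn3)o2)cc1`, has not been measured yet. It differs from compound 2 in a single spot: methylsulfanyl in place of chloro on an aromatic carbon. The rest of the molecule, including the long chain and the shared core, is unchanged.

Within the data shown here, no measured pair here isolates this exchange, so the expectation rests on the closeness of the two groups alone. Compound 3 is expected to stay near compound 2, with the step from compound 2 to compound 3 estimated as a 1.7-fold higher number from compound 2 to compound 3 (0.22 log units; within the scatter), at or barely beyond the scatter. The estimate for compound 3 is 4.5 nM, within a range from 1.5 nM to 15 nM.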

Compound 3, inhibition constant: 2.5 nM
The estimate for compound 3 lay 1.8-fold (0.26 log units) above the measured number; the range from low to high includes it.
By their numbers in this assay, from the lowest: compounds 3 and 2 (each within the scatter of the next); then compound 1.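

In this assay, the step is a 1.1-fold lower number from compound 2 to compound 3 (0.03 log units; within the scatter) and so gives no way to tell the two compounds apart. Among these compounds, this is the first comparison here in which only one place differs, and it shows that this spot on the six-membered aromatic ring, para to a large group, takes methylsulfanyl in place of chloro with no change in inhibition beyond the scatter. The entering group has two heavy atoms rather than one and counts one hydrogen-bond acceptor where chloro counts none, yet the number stays within the scatter, and no evidence on hand says why the two groups give such close values.

From the compounds shown here alone, whether the same spot would also tolerate an amine, a carboxylic acid or a methoxy group remains open, since two closely matched groups say little about very different ones. Going by these compounds, compound 1 still differs from compound 2 and compound 3 in more than one place, so it remains unknown whether its chain, its pyridine ring or both account for its gap to them.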